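Thiophen-2-yl in place of 4-fluorophenyl on a triple-bonded carbon

This account rests on a few compounds, and the source may have more. Where it says the series, first, only, none or still open, it means among the compounds named here.

In a functional assay on Z-138 cells (Homo sapiens) for antiproliferative activity, with a stated time of 72 h (a lower number here means a stronger inhibitor, a higher number a weaker inhibitor), three compounds that share one core and differ only in the group on a triple-bonded carbon have been measured. Compound 1 (`CCCCC#Cc1cc([C@@H]2O[C@H](CO)[C@@H](O)[C@H]2O)n2ncnc(N)c12`) with butyl gives 200 nM and compound 2 (`Nc1ncnn2c([C@@H]3O[C@H](CO)[C@@H](O)[C@H]3O)cc(C#CC3CC3)c12`) with cyclopropyl gives 20 nM while compound 3 (`Nc1ncnn2c([C@@H]3O[C@H](CO)[C@@H](O)[C@H]3O)cc(C#Cc3ccc(F)cc3)c12`) with 4-fluorophenyl stands highest at 89000 nM and is the weakest inhibitor of the three. Compound 4 (`Nc1ncnn2c([C@@H]3O[C@H](CO)[C@@H](O)[C@H]3O)cc(C#Cc3cccs3)c12`) keeps the core and carries thiophen-2-yl in place of 4-fluorophenyl on a triple-bonded carbon. Going by the values given here, three measured steps bear on this change, all made at that same place. The step from butyl to cyclopropyl was modest (a 10-fold lower number from compound 1 to compound 2 (1.00 log units; beyond the scatter)), whereas the two steps to 4-fluorophenyl were large (a 450-fold higher number from compound 1 to compound 3 (2.65 log units; beyond the scatter) and a 4500-fold higher number from compound 2 to compound 3 (3.65 log units; beyond the scatter)). Among the compounds with values here, no measured compound carries a five-membered aromatic ring, so the size of the next step is poorly fixed. With compound 3 at 89000 nM so far above the other two, a lower number is expected, though only a partial return, since an aromatic ring stays in place. The expected change is a sizeable drop (a 30-fold lower number from compound 3 to compound 4 (1.47 log units; beyond the scatter)) in this assay by this estimate. Compound 4 is estimated at 3000 nM with an expected range from 200 nM to 50000 nM in this measurement.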

Compound 4, half-maximal inhibitory concentration: 50100 nM
Estimate against measurement, compound 4: 17-fold (1.22 log units) below, outside the stated range (above it).
By their numbers in this assay, from the lowest: compound 2; then compound 1; then compounds 4 and 3 (each within the scatter of the next).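

In this assay the change from 4-fluorophenyl to thiophen-2-yl gives a 1.8-fold lower number from compound 3 to compound 4 (0.25 log units; within the scatter) and thus leaves the number within the scatter, although the two groups differ in ring size, in heavy atoms and in the hetero atom. Compound 4 stays far from the compounds with butyl and cyclopropyl on the triple-bonded carbon (a 250-fold higher number from compound 1 to compound 4 (2.40 log units; beyond the scatter); a 2500-fold higher number from compound 2 to compound 4 (3.40 log units; beyond the scatter)), so the large step seen with compound 3 is no longer tied to the 4-fluorophenyl group alone but is shared by both aromatic rings shown, with no compound here going against this. Nothing measured here accounts for the gap between these two aromatic groups and the other two groups, so its cause stays unassigned.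

Going by these compounds, whether the high numbers extend to aromatic rings in general remains open, and an unsubstituted phenyl or a pyridine ring at this place would test that. On these data alone, it is also open how far the low numbers extend beyond butyl and cyclopropyl, for instance to cyclobutyl, to a longer chain or to a chain ending in an amine.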